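A few compounds are considered here, and "the series" means these few. Any claim that something is new, unique, unknown or untested is made for them only; others in the source may bear on it.

Measured so far in an assay on cells for antagonist activity at transient receptor potential cation channel subfamily V member 1 (Homo sapiens), read by FLIPR and calcium flux, with a stated time of 6 min; a lower number here means a stronger inhibitor, a higher number a weaker inhibitor:
compound 1, `CC(C(=O)NCc1ccc(C(C)(C)C)nc1SCCCN1CCCC1)c1ccc(NS(C)(=O)=O)c(F)c1`: 17.1 nM
compound 2, `CC(C(=O)NCc1ccc(C(C)(C)C)nc1SCc1ccccc1)c1ccc(NS(C)(=O)=O)c(F)c1`: 4 nM
compound 3, `CCCCN(C)c1cc(C(C)(C)C)ccc1CNC(=O)C(C)c1ccc(NS(C)(=O)=O)c(F)c1`: 1 nM

Compound 3 gives the lowest number of the three in this assay; compound 2 stands a step above it and compound 1 further still, both gaps beyond the scatter. The next compound, compound 4, `CC(C(=O)NCc1ccc(C(C)(C)C)cc1OCc1ccccc1)c1ccc(NS(C)(=O)=O)c(F)c1`, differs from compound 3 as follows: benzyloxy in place of butyl(methyl)amino on an aromatic carbon.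

Within the data shown here, no measured step alters this position on the core of compound 3 directly. Among the measured compounds shown here, the one measured step, a 4.3-fold lower number from compound 1 to compound 2 (0.63 log units; beyond the scatter), concerns a different core and a different attachment atom, yet it also replaced a nitrogen-bearing chain with a phenyl-carrying group and gave a modest gain, beyond the scatter. The present change likewise removes a nitrogen-bearing chain and brings in a benzyl-type group, and compound 4 thereby comes to resemble compound 2, which gives 4 nM in this assay. Compound 4 is therefore expected to land near compound 2 rather than to improve on compound 3. Relative to compound 3, the expected step is a 4.0-fold higher number from compound 3 to compound 4 (0.60 log units; beyond the scatter). For compound 4 the expected value is 4 nM, with a range from 1.3 nM to 12 nM.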

Compound 4, inhibition constant: 2.9 nM
Estimate against measurement, compound 4: 1.4-fold (0.14 log units) above, and the stated range covers the measured number.
By their numbers in this assay, from the lowest: compound 3; then compounds 4 and 2 (each within the scatter of the next); then compound 1.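

In this assay, among these compounds, a 2.9-fold higher number from compound 3 to compound 4 (0.46 log units; beyond the scatter) gives the first direct reading at this position on the core of compound 3, on the aromatic carbon ortho to a large group and meta to a tert-butyl group. Going from butyl(methyl)amino, with no ring, to benzyloxy, with its six-membered aromatic ring, gives a modest rise, and compound 4 still reaches 2.9 nM, so this position accepts both an open-chain amino group and a ring-bearing ether. The step changes the attached atom and the group beyond it together, so the two contributions cannot be separated, and no measurement here accounts for the size of the step.

The compounds shown leave open whether the rise follows the oxygen or the phenyl ring, a question that butoxy or benzyl(methyl)amino at this position would address. They also leave open how far the position tolerates other substituents, such as a longer alkoxy chain or a chain ending in an amine or a carboxylic acid.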